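Trimming an isopropyl to a methyl on the saturated ring

The source may report more compounds than this note shows. Statements on the series, on what has been measured and on what is new or still open speak of the compounds shown alone.

Measured so far:
compound 1 `Cc1cc2c(cc1C(=O)N=C(N)N)S(=O)(=O)CCC2C`: 45 nM
compound 2 `Cc1cc2c(cc1C(=O)N=C(N)N)S(=O)(=O)CC2C(C)C`: 21 nM

Both compounds were tested in an assay on cells for inhibition of sodium/hydrogen exchanger (Oryctolagus cuniculus); on this read-out lower numbers stand for stronger inhibition and higher numbers for weaker inhibition. Compound 2 has the lowest number of the two; its nearest neighbour, compound 1, sits at a higher number, a gap beyond the usual scatter. Compounds 1 and 2 differ from each other in more than one place, so no single change can be credited with that gap.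

Compound 3 `Cc1cc2c(cc1C(=O)N=C(N)N)S(=O)(=O)CC2C` has not yet been measured. It differs from compound 2 in one place: methyl in place of isopropyl on a saturated ring carbon. Among the compounds with values here, no measured pair shows this change alone. With compound 1 carrying a methyl at a comparable kind of position and giving 45 nM, a modest shift toward a higher number seems plausible, yet it may well stay within the scatter.

Compound 3 is therefore expected at 35 nM, between 12 nM and 100 nM. The step expected from compound 2 to compound 3 is a 1.7-fold higher number from compound 2 to compound 3 (0.22 log units; within the scatter).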

Compound 3, half-maximal inhibitory concentration: 44 nM
For compound 3 the middle estimate is 1.3-fold (0.10 log units) below the measured one; the range from low to high includes it.
By their numbers in this assay, from the lowest: compound 2; then compounds 3 and 1 (each within the scatter of the next).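

In this assay, within the data shown here, replacing the isopropyl with a methyl on this saturated ring carbon, two ring bonds from the ring sulfur, gives a 2.1-fold higher number from compound 2 to compound 3 (0.32 log units; beyond the scatter), and this is the only change here that can be read on its own. The group at this carbon therefore does register in the read-out, but the step is modest: with 1 heavy atom in place of 3, compound 3 still gives 44 nM and remains an inhibitor in the nanomolar range. Nothing shown here explains why the isopropyl gives the lower number.

Only these two groups are compared at this carbon, so two points cannot be called a trend with size. On these data alone, it stays open whether a longer chain such as butyl would lower the number further, and how an amine or a plain hydrogen at this carbon would compare.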